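Methyl on an amide-type nitrogen of compound 2

The source may report more compounds than this note shows. Statements on the series, on what has been measured and on what is new or still open speak of the compounds shown alone.

Of the compounds shown here, two have been measured so far in a physicochemical assay for solubility, at pH 7.4; on this read-out higher numbers stand for higher solubility and lower numbers for lower solubility. Compound 1 `CN(C(=O)c1cc(-c2ccccc2Cl)on1)[C@H]1CN(S(=O)(=O)c2ccccc2)C[C@@H]1C(=O)N[C@H]1CCCNC1` reads 655000 nM, while compound 2 `CN(C(=O)[C@H]1CN(S(=O)(=O)c2ccccc2)C[C@@H]1NC(=O)c1cc(-c2ccccc2Cl)on1)[C@H]1CCCNC1` reads 113000 nM. This places compound 2 as the lower of the two, with a gap beyond the usual scatter. The pair differ in more than one place, however, so their gap is no guide to a single change. Compound 3 `CN(C(=O)[C@H]1CN(S(=O)(=O)c2ccccc2)C[C@@H]1N(C)C(=O)c1cc(-c2ccccc2Cl)on1)[C@H]1CCCNC1` departs from compound 2 at one point: methyl in place of hydrogen on an amide-type nitrogen. For the measured compounds named here, no measured pair shows this change, so only a small upward step in this assay is expected, one that stays within the scatter. The value expected for compound 3 is 170000 nM, with an estimated range of 65000 nM to 450000 nM. This estimate amounts to an expected step of a 1.5-fold higher number from compound 2 to compound 3 (0.18 log units; within the scatter).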

Compound 3, solubility: 553000 nM
Estimate against measurement, compound 3: 3.3-fold (0.51 log units) below, outside the stated range (above it).
By their numbers in this assay, from the lowest: compound 2; then compounds 3 and 1 (each within the scatter of the next).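

In this assay, for the compounds shown here, methyl in place of hydrogen on an amide-type nitrogen gives a 4.9-fold higher number from compound 2 to compound 3 (0.69 log units; beyond the scatter), a first reading of this change, and one that lies beyond the scatter. The same change on the other amide-type nitrogen gives a 1.2-fold lower number from compound 1 to compound 3 (0.07 log units; within the scatter), which stays within the scatter, so in these compounds the outcome depends on which of the two nitrogens receives the methyl. No available evidence bears on why the two steps part.

Each step is a single reading, and both end at compound 3, which carries methyl on both nitrogens, so neither shows how the change behaves with hydrogen on the other nitrogen. The compounds shown also leave open whether an ethyl group or a longer chain on either nitrogen would read like methyl.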